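A few compounds are considered here, and "the series" means these few. Any claim that something is new, unique, unknown or untested is made for them only; others in the source may bear on it.

In a functional assay on SGC-7901 cells (Homo sapiens) for antiproliferative activity, read by sulforhodamine B assay, with a stated time of 72 h (a lower number here means a stronger inhibitor, a higher number a weaker inhibitor), compound 3 `S=C(N/N=C/c1ccc2ccccc2n1)Nc1ccc(Cl)cc1` gives 87600 nM. Compound 2 `Cc1ccc(NC(=S)N/N=C/c2ccc3ccccc3n2)cc1` gives 92900 nM, and a 1.1-fold lower number from compound 2 to compound 3 (0.03 log units; within the scatter) means that the two cannot be told apart. Compound 1 `COc1ccccc1NC(=S)N/N=C/c1ccc2ccccc2n1` gives > 100000 nM, which is a limit of the assay and not a number.

The next structure is compound 4 `S=C(N/N=C/c1ccc2ccccc2n1)Nc1ccccc1Br`, where 2-bromophenyl takes the place of 4-chlorophenyl on an amide-type nitrogen: 2-bromophenyl in place of 4-chlorophenyl on an amide-type nitrogen. The measured steps that bear on this swap are those that also change this group or its substituent. They are an at least 1.0-fold lower number from compound 1 to compound 2 (0.03 log units; that floor lies within the scatter), an at least 1.1-fold lower number from compound 1 to compound 3 (0.05 log units; that floor lies within the scatter) and a 1.1-fold lower number from compound 2 to compound 3 (0.03 log units; within the scatter). All three stay within the scatter, although the first two are only floors set by a limit. Among the measured compounds, 2-methoxyphenyl in compound 1 is the closest match by name to 2-bromophenyl.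

On this basis, no change beyond the scatter is expected in this assay, with a slight risk of a weaker result. The expected step is a 1.0-fold lower number from compound 3 to compound 4 (0.01 log units; within the scatter). The estimate for compound 4 is 85000 nM, with an expected range from 35000 nM to 150000 nM.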

Compound 4, half-maximal inhibitory concentration: > 100000 nM
Compound 4 was reported as a limit; the forecaster's own chance of this, stated with the estimate: 35%; at least 1.1-fold (0.07 log units) between middle value and limit.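

In this assay, compound 4 gives > 100000 nM, which is a limit of the assay and not a number. As far as these compounds go, the swap gives an at least 1.1-fold higher number from compound 3 to compound 4 (0.05 log units; that floor lies within the scatter), and the change from the methyl-bearing ring gives an at least 1.0-fold higher number from compound 2 to compound 4 (0.03 log units; that floor lies within the scatter), so neither step shows a real change and the true size of each remains unknown. What is new is that 2-bromophenyl, like 2-methoxyphenyl, gives no number on this nitrogen, and comparison is limited because the readings run into the same ceiling: the limit of > 100000 nM in this assay, at which 2 of the 4 values shown sit.

The step between compound 1 and compound 4 cannot be read, since both values are limits, so bromo and methoxy cannot be separated here. Also open, from the compounds shown here alone, is whether an amine or a carboxylic acid on the phenyl ring would give a number clearly beyond the scatter from these compounds.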